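Notes on the sulfonamide series: expectation for compound 4

This account rests on a few compounds, and the source may have more. Where it says the series, first, only, none or still open, it means among the compounds named here.

Of the compounds shown here, three sharing one core have been measured in a functional assay for agonist activity at growth hormone secretagogue receptor type 1 (Homo sapiens), read by FLIPR; on this read-out lower numbers stand for smaller maximal responses and higher numbers for larger maximal responses. Compound 1 `COc1ccc(N2C[C@@H](C)N[C@@H](C)C2)cc1NS(=O)(=O)c1ccc(-c2ccccc2)cc1` carries phenyl at the varied aromatic carbon and gives 1. Compound 2 `COc1ccc(F)c(-c2ccc(S(=O)(=O)Nc3cc(N4C[C@@H](C)N[C@@H](C)C4)ccc3OC)cc2)c1` carries 2-fluoro-5-methoxyphenyl at that carbon and gives 1.2. Compound 3 `COc1ccc(N2C[C@@H](C)N[C@@H](C)C2)cc1NS(=O)(=O)c1ccc(N2CCCC2=O)cc1` carries 2-oxopyrrolidin-1-yl and gives 0.8, the lowest of the three numbers. The measured steps run a number 0.20 higher from compound 1 to compound 2 (beyond the scatter), a number 0.20 lower from compound 1 to compound 3 (beyond the scatter) and a number 0.40 lower from compound 2 to compound 3 (beyond the scatter), so both aromatic groups stand above the non-aromatic one.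

Compound 4 `COc1ccc(N2C[C@@H](C)N[C@@H](C)C2)cc1NS(=O)(=O)c1ccc(-c2cccs2)cc1` is not yet measured. It differs from compound 3 in one place: thiophen-2-yl in place of 2-oxopyrrolidin-1-yl on an aromatic carbon. Going by the values given here, the steps that bear on this change are the two leading into compound 3, a number 0.20 lower from compound 1 to compound 3 (beyond the scatter) and a number 0.40 lower from compound 2 to compound 3 (beyond the scatter). Both show that exchanging an aromatic ring at this carbon for 2-oxopyrrolidin-1-yl lowered the maximal response. Thiophen-2-yl, like phenyl, is an aromatic ring without further substituents, so the reverse change is expected to raise the response by roughly the size of the phenyl step rather than the larger one. The step expected is a number 0.20 higher from compound 3 to compound 4 (beyond the scatter). For compound 4 the estimate in this assay is 1, with a range from 0.85 to 1.15.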

Compound 4, intrinsic activity: the largest response reached, as a fraction of the reference agonist's: 1
Estimate against measurement, compound 4: no gap at the digits printed, and the stated range covers the measured number.
By their numbers in this assay, from the lowest: compound 3; then compounds 1 and 4 (each within the scatter of the next); then compound 2.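

In this assay, the exchange of phenyl for thiophen-2-yl gives no change at the digits printed from compound 1 to compound 4 (within the scatter), so a five-membered aromatic ring with one hetero atom and a six-membered carbon ring cannot be told apart at this aromatic carbon. The change from 2-oxopyrrolidin-1-yl to thiophen-2-yl gives a number 0.20 higher from compound 3 to compound 4 (beyond the scatter), which makes this the first direct step upward from compound 3 and places all three aromatic groups shown above the non-aromatic ring. The exchange of 2-fluoro-5-methoxyphenyl for thiophen-2-yl gives a number 0.20 lower from compound 2 to compound 4 (beyond the scatter), so among these compounds the higher response goes with the substituted aromatic ring alone and is not matched by either unsubstituted ring, though that rests on compound 2 only.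

The compounds shown leave open whether the fluoro group, the methoxy group or both account for compound 2, and how a pyridin-3-yl ring, a morpholin-4-yl group or a carboxylic acid would fare at this carbon. The data shown offer no measurement that explains any of these steps.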